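Dimethylamino in Place of Phenoxy: Compound 3 to Compound 4

A few compounds are considered here, and "the series" means these few. Any claim that something is new, unique, unknown or untested is made for them only; others in the source may bear on it.

Of the compounds shown here, three share a core and have been measured in a functional assay on HOP-92 cells (Homo sapiens) for cytotoxicity, read by sulforhodamine B assay, with a stated time of 48 h, tested at 0.001 uM; on this read-out lower numbers stand for a stronger effect and higher numbers for a weaker effect at the one concentration tested. Compound 1 `COc1cc(C)cc(-c2c(-c3ccnc(-c4ccc(C(C)=O)cc4)c3)cnn2CC#N)c1` gives 84%, and compound 2 `COc1cc(C)cc(-c2nn(CC#N)cc2-c2ccc(-c3cccc(C(C)=O)c3)nc2)c1` gives 84%. Compound 3 `Cc1cc(O)cc(-c2nn(CC#N)cc2-c2ccnc(-c3ccc(Oc4ccccc4)cc3)c2)c1` gives 74% in this assay. On the numbers shown, compound 3 carries the smallest of the three values, yet both the value of compound 1 and the value of compound 2 lie within the usual scatter of it, so no real separation between the three can be claimed.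

Compound 4 `Cc1cc(O)cc(-c2nn(CC#N)cc2-c2ccnc(-c3ccc(N(C)C)cc3)c2)c1` has not yet been measured. It differs from compound 3 in one place: dimethylamino in place of phenoxy on an aromatic carbon. Going by the values given here, no pair of measured compounds shows a change of this kind, so nothing in the data points to a direction. The step from compound 3 to compound 4 is therefore expected to be a number 4 percentage points higher from compound 3 to compound 4 (within the scatter), that is, not beyond the scatter. In this assay compound 4 is estimated to give 78%, with a likely range from 62% to 92%.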

Compound 4, a percentage reported as activity, at one concentration (the size of the read-out at that concentration, not a potency): 80%
For compound 4 the middle estimate is 2 percentage points below the measured one; the range from low to high includes it.
By their numbers in this assay, from the lowest: compounds 3, 4, 1 and 2 (each within the scatter of the next).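

Going by these compounds alone, the change of dimethylamino in place of phenoxy on an aromatic carbon, para to a large group, gives the first step that can be read at this position in this assay: a number 6 percentage points higher from compound 3 to compound 4 (within the scatter). An aromatic ring of carbon only thus gives way to a group with no ring, and the read-out at this one concentration stays within the scatter, so the phenoxy ring is not shown to matter for this number. No measured property of either group accompanies the result, and what lies behind it remains unknown.

The compounds shown leave open whether any group at this position can move the read-out beyond the scatter. A carboxylic acid, a primary amine or a morpholine ring in the same place would remain to be compared.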